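The compounds below may be only part of what the source reports. "The series", "measured", "known", "first", "only" and "open" are said of these compounds alone.

The measured compounds and their values:

compound 1, `CC(=O)c1c(NNc2ccc(Cl)cc2)cc(C)oc1=O`, gives 54.4%
compound 2, `CC(=O)c1c(NNc2nc3ccccc3s2)cc(C)oc1=O`, gives 64.6%
compound 3, `Cc1ccc(-n2nc3cc(C)oc(=O)c3c2C)cc1`, gives 63.3%

These three numbers come from a functional assay on the whole organism for inhibition, with Rattus norvegicus as the target, read by paw edema, with a stated time of 1 h, at a dose of 50 mg/kg; on this read-out higher numbers stand for more inhibition at the one dose given (going by the name of the read-out) and lower numbers for less inhibition. Compound 3 stands second highest of the three. Its nearest neighbour is compound 2, whose number lies a little higher, a gap that falls within the usual scatter of repeated measurements. The furthest is compound 1, whose number lies lower, again by a gap within that scatter. So on the numbers shown, none of the three can be told apart with confidence; they sit in one band.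

Compound 4, `COc1ccc(-n2nc3cc(C)oc(=O)c3c2C)cc1`, is not yet measured. It differs from compound 3 in one place: methoxy in place of methyl on an aromatic carbon. For the measured compounds named here, no pair of measured compounds differs by a single change, so there is no measured step to lean on for how large an effect such a swap has in this assay.

Given that, a small step is expected, in no particular direction, not beyond the scatter. Compound 4 is estimated to give about 62%, with a range from 46% to 78%. The step this estimate means, a number 1.3 percentage points lower from compound 3 to compound 4 (within the scatter), is expected to stay within the scatter.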

Compound 4, a percentage reported as inhibition, in the whole organism at one dose (the size of the read-out at that dose, not a potency): 64.6%
Estimate against measurement, compound 4: 2.6 percentage points below; measured number inside the range.
By their numbers in this assay, from the lowest: compounds 1, 3, 2 and 4 (each within the scatter of the next, the first and the last beyond it).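

The pair of compound 3 and compound 4 is the only one here that differs in one place, and in this assay it gives a number 1.3 percentage points higher from compound 3 to compound 4 (within the scatter) for methoxy in place of methyl on an aromatic carbon para to a large group. For the compounds shown here, this gives the first direct reading at this position: adding an oxygen and a hydrogen-bond acceptor to the group there leaves the two compounds impossible to tell apart on this read-out. Nothing measured here explains this outcome.

The compounds shown leave open whether a different group at this position, such as an amine, a carboxylic acid or a longer chain like butoxy, would shift the number beyond the scatter. They also leave open how methyl and methoxy compare with plain hydrogen in that place, and whether the same picture would hold at other doses or at other times.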